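Cutting the Benzyl Group: What Compound 3 Might Show

The source may report more compounds than this note shows. Statements on the series, on what has been measured and on what is new or still open speak of the compounds shown alone.

Compound 1, `C[Si](C)(C)CCOCn1c(CC(O)(CO)CO)cc(=O)[nH]c1=O`: in a functional assay on HepG2 cells (Homo sapiens) for antiproliferative activity, read by MTT assay, with a stated time of 72 h (a higher number here means a weaker inhibitor, a lower number a stronger inhibitor), compound 1 gives > 100000 nM, which is a limit of the assay and not a number.
Compound 2, `C[Si](C)(C)CCOCn1c(CC(O)COCc2ccccc2)cc(=O)[nH]c1=O`: in this assay compound 2 gives > 100000 nM, again a limit of the assay rather than a number.

Compound 2 thus stands only at a limit in this assay. For the measured compounds named here, the one further value shown is also a limit, as the limit of > 100000 nM in this assay, at which 2 of the 2 values shown sit, records, so no measured step between compounds exists to calibrate against. Compound 3, `C[Si](C)(C)CCOCn1c(CC(O)CO)cc(=O)[nH]c1=O`, differs from compound 2 by hydrogen in place of benzyl on an oxygen on a saturated carbon. With both known values sitting at the limit, no step beyond the scatter is expected in this assay, in either direction, and the most likely outcome is a third limit. Compound 3 is therefore estimated at 100000 nM, with an expected range from 30000 nM to 300000 nM, which amounts to an expected step of a number no higher from compound 2 to compound 3 (the limit leaves the size open).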

Compound 3, half-maximal inhibitory concentration: > 100000 nM
Compound 3 ended at the assay's limit (the forecaster's own chance of this, stated with the estimate: 85%); the middle value lies on the limit itself.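

No step can be read from compound 2 to compound 3 or from compound 1 to compound 3, because all three compounds stand at one limit, which is not a number: the limit of > 100000 nM in this assay, at which 3 of the 3 values shown sit.

These compounds leave open how they truly compare in this assay and whether removing benzyl or hydroxymethyl changes anything there.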